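The compounds below may be only part of what the source reports. "The series", "measured", "known", "first", "only" and "open" are said of these compounds alone.

Working notes on the series:
- Compound 1 `CCCSc1ncnc2ccc(I)cc12`: 29000 nM
- Compound 2 `CCSc1ncnc2ccc(I)cc12`: 31100 nM

In a functional assay on BGC-823 cells (Homo sapiens) for antiproliferative activity, read by MTT assay (on this read-out higher numbers stand for weaker inhibition and lower numbers for stronger inhibition), compound 2 gives 31100 nM, within the scatter of compound 1, so the two cannot be ordered. Compound 3 `C=CCSc1ncnc2ccc(I)cc12` is the next to be read, and its change from compound 2 is vinyl in place of methyl on a saturated chain carbon bound to a sulfur.

Within the data shown here, the one measured step that bears on this is a 1.1-fold higher number from compound 1 to compound 2 (0.03 log units; within the scatter), which is hydrogen in place of methyl on a saturated chain carbon, two bonds along the chain from a sulfur. Among the measured compounds shown here, no measured compound carries a double bond outside aromatic rings, so this step is only a loose guide. On the strength of that small step, no change beyond the scatter is expected in this assay. The expected step is a 1.1-fold lower number from compound 2 to compound 3 (0.05 log units; within the scatter). For compound 3 the estimated value is 28000 nM, with an expected range of 15000 nM to 50000 nM.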

Compound 3, half-maximal inhibitory concentration: 33200 nM
Compound 3: the middle estimate sits 1.2-fold (0.07 log units) below what was measured; the range from low to high includes it.
By their numbers in this assay, from the lowest: compounds 1, 2 and 3 (each within the scatter of the next).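

Vinyl in place of methyl on a saturated chain carbon bound to a sulfur gives a 1.1-fold higher number from compound 2 to compound 3 (0.03 log units; within the scatter) in this assay and so adds a double bond outside aromatic rings without a change that can be read. Set against the chain of compound 1, vinyl in place of ethyl at the same carbon gives a 1.1-fold higher number from compound 1 to compound 3 (0.06 log units; within the scatter) and this comparison also separates nothing. All the changes at this carbon now shown, including the first one to bring in an unsaturated chain, leave the compounds unordered. No supporting evidence bears on this result.

On these data alone, whether any group on this chain can move the number beyond the scatter stays open, for example a terminal amine, a carboxylic acid, a benzyl group or a much longer chain. The compounds shown also leave open how far the iodine on the shared core contributes to the activity.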